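Capping a Hydroxy Group on Compound 2

The source may report more compounds than this note shows. Statements on the series, on what has been measured and on what is new or still open speak of the compounds shown alone.

For the measured compounds named here, in an ADME assay on HEK293 cells (Homo sapiens) for cytotoxicity, read by MTT assay, with a stated time of 48 h (a higher number here means a weaker inhibitor, a lower number a stronger inhibitor), compound 1 `COc1ccc(/C=C2/S/C(=N/c3ccccc3)N(Cc3ccncc3)C2=O)cc1` gives 47900 nM and compound 2 `O=C1/C(=C\c2ccc(O)c(O)c2)S/C(=N/c2ccccc2)N1Cc1ccncc1` gives 230000 nM, the higher of the only two numbers measured so far. Compound 3 `COc1cc(/C=C2/S/C(=N/c3ccccc3)N(Cc3ccncc3)C2=O)ccc1O` keeps the shared core of compound 2 and alters it in a single place: methyl in place of hydrogen on an oxygen on an aromatic ring. This is methyl in place of hydrogen on an oxygen on an aromatic ring, so a hydroxy becomes a methoxy and 3,4-dihydroxyphenyl becomes 4-hydroxy-3-methoxyphenyl.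

Going by the values given here, only one measured step bears on this change. With 3,4-dihydroxyphenyl in place of 4-methoxyphenyl, the data show a 4.8-fold higher number from compound 1 to compound 2 (0.68 log units; beyond the scatter). The new group of compound 3 holds a methoxy, as 4-methoxyphenyl does, and a hydroxy, as 3,4-dihydroxyphenyl does. A single pair is thin evidence, but it points to a partial move back toward compound 1, so a modest drop in this assay is expected. The estimated change is a 2.2-fold lower number from compound 2 to compound 3 (0.34 log units; beyond the scatter). For compound 3 the expected value is 105000 nM, with an estimated range of 50000 nM to 220000 nM.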

Compound 3, half-maximal inhibitory concentration: 67400 nM
Beside the measured number, compound 3's estimate is 1.6-fold (0.19 log units) above it; the measured number falls inside the stated range.
By their numbers in this assay, from the lowest: compounds 1 and 3 (each within the scatter of the next); then compound 2.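

Compound 1 and compound 2 differ in the whole aromatic group, so their pair could not isolate a single atom change, whereas this pair does. In this assay, putting methyl in place of hydrogen on an oxygen on an aromatic ring, which turns one hydroxy into a methoxy, gives a 3.4-fold lower number from compound 2 to compound 3 (0.53 log units; beyond the scatter). That one added carbon accounts for most of the gap between the first two compounds, since the remaining difference is a 1.4-fold higher number from compound 1 to compound 3 (0.15 log units; within the scatter), so the 4-hydroxy-3-methoxyphenyl and 4-methoxyphenyl compounds cannot be told apart here, even though compound 3 still carries a hydroxy. No measurement offered here explains why capping this hydroxy shifts the number.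

The compounds shown leave open whether capping the other hydroxy as well, to give 3,4-dimethoxyphenyl, would change the number any further. They also leave open whether ethyl, a longer chain on the same oxygen, would behave as methyl does, or whether an amine in place of this hydroxy would give a similar result.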